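Series notes: carbamoyl to methyl on the piperidine tail

The source may report more compounds than this note shows. Statements on the series, on what has been measured and on what is new or still open speak of the compounds shown alone.

Measured so far:
compound 1 `CN(C)CCCOc1ccccc1/C=C/c1ccccc1`: 14.2%
compound 2 `NC(=O)C1CCCN(CCCCOc2ccccc2/C=C/c2ccccc2)C1`: 0%

Both compounds share the same core and differ only in the amine-bearing tail. In a functional assay on the whole organism with Mus musculus as the target, in the maximal electroshock model, at a dose of 50 mg/kg by the oral route (on this read-out lower numbers stand for less inhibition and higher numbers for more inhibition at the one dose given (going by the name of the read-out)), compound 1 gives 14.2%, and compound 2 gives 0%. Compound 2 therefore stands lowest of the two numbers; its gap to compound 1 lies beyond the usual scatter of this assay.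

Compound 3 `CC1CCCN(CCCCOc2ccccc2/C=C/c2ccccc2)C1` is not yet measured. It keeps the tail of compound 2 and alters one group: methyl in place of carbamoyl on a saturated ring carbon. For the measured compounds named here, no pair of measured compounds differing in a single place is available, so the size of this step is not known from the data.

The expectation for compound 3 leans on compound 1, which gives 14.2% in this assay with a tail that likewise lacks a carbamoyl. For compound 3 the estimated value in this assay is 10%, with a range from 0% to 28%. That estimate means an expected step of a number 10 percentage points higher from compound 2 to compound 3 (within the scatter), upward, about the size of the scatter or not clearly beyond it.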

Compound 3, a percentage reported as inhibition, in the whole organism at one dose (the size of the read-out at that dose, not a potency): 12.5%
For compound 3 the middle estimate is 2.5 percentage points below the measured one, within the range that was stated.
By their numbers in this assay, from the lowest: compound 2; then compounds 3 and 1 (each within the scatter of the next).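

In this assay, for the compounds shown here, the change from 3-carbamoylpiperidin-1-yl to 3-methylpiperidin-1-yl provides the first single-place step, a number 12.5 percentage points higher from compound 2 to compound 3 (beyond the scatter), so a change at this saturated ring carbon, two ring bonds from the ring nitrogen, can shift the read-out by a modest amount beyond the scatter. The step of a number 1.7 percentage points lower from compound 1 to compound 3 (within the scatter) shows that the tail of compound 3 and the dimethylamino tail of compound 1 cannot be told apart at this one dose, so in this small set the methyl-bearing piperidine tail gives a result comparable to that of the dimethylamino tail. Nothing available bears on the reason for the step at this ring carbon.

Going by these compounds, it remains open whether a hydroxyl, a carboxylic acid or a primary amine on the same ring carbon would give a number nearer that of compound 2 or that of compound 3. On these data alone, it also remains open how a longer chain between the aromatic-ring oxygen and the piperidine nitrogen would affect the read-out, and whether any of these tails would separate more clearly at another dose.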